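Aminothiophene ketones: piperazine substituent survey

The compounds below may be only part of what the source reports. "The series", "measured", "known", "first", "only" and "open" are said of these compounds alone.

Compound 1 `Nc1scc(CN2CCN(C3CCCCC3)CC2)c1C(=O)c1ccc(Cl)cc1` gives 1.9 nM in an assay on CHO cells for displacement of a labelled ligand from adenosine receptor A1 (Homo sapiens); a higher number here means weaker binding, a lower number tighter binding. Compound 2 `Nc1scc(CN2CCN(c3ccc(F)cc3)CC2)c1C(=O)c1ccc(Cl)cc1` gives 1.8 nM in this assay. The one measured step, a 1.1-fold lower number from compound 1 to compound 2 (0.02 log units; within the scatter), exchanges the whole group on the ring amine nitrogen, so on the numbers shown compound 2 stands alongside compound 1 with no separation beyond the scatter.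

Compound 3 `Cc1ccc(N2CCN(Cc3csc(N)c3C(=O)c3ccc(Cl)cc3)CC2)cc1` carries methyl in place of fluoro on an aromatic carbon. For the measured compounds named here, no measured step alters a substituent on that six-membered ring; the only step available, from compound 1 to compound 2, replaced the ring itself and stayed within the scatter, which gives no ground to expect a shift from a smaller change at its far end. The step from compound 2 to compound 3 in this assay is therefore expected to be a 1.1-fold higher number from compound 2 to compound 3 (0.05 log units; within the scatter), none beyond the scatter. Compound 3 is estimated at 2 nM, within a range of 0.8 nM to 5 nM.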

Compound 3, dissociation constant: 1.7 nM
For compound 3 the middle estimate is 1.2-fold (0.07 log units) above the measured one; measured number inside the range.
By their numbers in this assay, from the lowest: compounds 3, 2 and 1 (each within the scatter of the next).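

In this assay, for the compounds shown here, methyl in place of fluoro on an aromatic carbon, para to a large group, gives a 1.1-fold lower number from compound 2 to compound 3 (0.02 log units; within the scatter) and separates neither compound; this is the first change to a substituent on that ring rather than to the ring itself. The wider exchange of cyclohexyl for 4-methylphenyl gives a 1.1-fold lower number from compound 1 to compound 3 (0.05 log units; within the scatter) and so also stays within the scatter, leaving compounds 1, 2 and 3 unseparated. Nothing available explains why the numbers stay together.

On these data alone, whether this flat reading holds on the same aromatic carbon for a group less like fluoro or methyl, such as a carboxylic acid or an amine, stays open. Also open, as far as these compounds go, is what happens when an acetyl group, rather than a carbon ring, sits on the ring amine nitrogen.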